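The source may hold more compounds than are shown below. What is called first, only, known or untested is meant among the compounds shown, and "the series" means these compounds.

Measured compounds:
Compound 1 `COc1ccc(F)cc1Nc1cc(NC(=O)Nc2c(Cl)cccc2Cl)ncn1`: 38.1%
Compound 2 `COc1cc(NC(=O)Nc2cc(Nc3ccc(C)c(F)c3)ncn2)cc(OC)c1`: 30.6%
Compound 3 `CC(C)(C)c1ccc(Nc2cc(NC(=O)Nc3c(Cl)cccc3Cl)ncn2)cc1`: 22%

In a functional assay on NCI-H520 cells (Homo sapiens) for inhibition, read by MTT assay, with a stated time of 48 h, tested at 10 uM (on this read-out lower numbers stand for less inhibition and higher numbers for more inhibition at the one concentration tested (going by the name of the read-out)), compound 2 gives 30.6%, and this number cannot be told apart from those of compound 1 and compound 3, since each gap falls within the usual scatter of repeated measurements. All three compounds share a core, and none of them reaches even half inhibition in this assay.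

Compound 4 `COc1cc(NC(=O)Nc2cc(Nc3cc(Br)ccc3OC)ncn2)cc(OC)c1` has not yet been measured. Its structure differs from compound 2 in one place: 5-bromo-2-methoxyphenyl in place of 3-fluoro-4-methylphenyl on a nitrogen on an aromatic ring. The three measured compounds carry different aryl groups at this very position, yet their numbers all lie close together, so no step beyond the scatter is expected, with a number 0.6 percentage points lower from compound 2 to compound 4 (within the scatter) estimated as essentially flat. Compound 4 is therefore expected to give about 30%, within a range from 15% to 45%.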

Compound 4, a percentage reported as inhibition, at one concentration (the size of the read-out at that concentration, not a potency): 43.5%
For compound 4 the middle estimate is 13.5 percentage points below the measured one, within the range that was stated.
By their numbers in this assay, from the lowest: compounds 3, 2, 1 and 4 (each within the scatter of the next, the first and the last beyond it).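

In this assay the aryl group on this nitrogen does make a measurable difference: 5-bromo-2-methoxyphenyl in place of 3-fluoro-4-methylphenyl gives a number 12.9 percentage points higher from compound 2 to compound 4 (beyond the scatter) at this position. The change replaces several atoms at once, so this modest step belongs to the whole group and not to any single atom. Nothing available here explains the step.

Going by these compounds, whether the bromine or the methoxy group matters more remains open. So does the effect of an unsubstituted phenyl, or of an aryl group carrying a carboxylic acid, at this position.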